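Swapping a Piperidine for a Lactam Ring on the Core

The compounds below may be only part of what the source reports. "The series", "measured", "known", "first", "only" and "open" are said of these compounds alone.

Two compounds share a core carrying a four-carbon chain ending in a phenyl ring, and have been measured in an assay on HEK293 cells for inhibition of acid ceramidase (Homo sapiens), read by fluorescence, with stated times of 10 min and 3 h; a lower number here means a stronger inhibitor, a higher number a weaker inhibitor. Compound 1 `CCN1CCC(c2ccc3c(c2)oc(=O)n3C(=O)NCCCCc2ccccc2)CC1` gives 92 nM in this assay. For the measured compounds named here, compound 2 `CC(C)N1CCC(c2ccc3c(c2)oc(=O)n3C(=O)NCCCCc2ccccc2)CC1` gives 94 nM in this assay, the highest of the two numbers, with compound 1 nearest to it; the single measured step, a 1.0-fold higher number from compound 1 to compound 2 (0.01 log units; within the scatter), lies within the scatter and changes only the group on the amine nitrogen in the ring.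

Compound 3 `CN1CCN(c2ccc3c(c2)oc(=O)n3C(=O)NCCCCc2ccccc2)C(=O)C1` differs from compound 2 at another place: 4-methyl-2-oxopiperazin-1-yl in place of 1-isopropylpiperidin-4-yl on an aromatic carbon. Going by the values given here, no measured step touches the group on the aromatic carbon of the core, so nothing among the two numbers tells how this assay answers such an exchange, and the expectation must stay broad. The step from compound 2 is expected to be a 2.7-fold higher number from compound 2 to compound 3 (0.42 log units; beyond the scatter), leaning toward a somewhat weaker inhibitor. Compound 3 is therefore estimated at 250 nM in this assay, within a range from 50 nM to 1500 nM.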

Compound 3, half-maximal inhibitory concentration: 52 nM
Compound 3: middle estimate off by 4.8-fold (0.68 log units), on the high side; low and high end bracket the measured number.
By their numbers in this assay, from the lowest: compounds 3, 1 and 2 (each within the scatter of the next).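

On the aromatic carbon of the shared core, 4-methyl-2-oxopiperazin-1-yl can take the place of 1-isopropylpiperidin-4-yl with only a 1.8-fold lower number from compound 2 to compound 3 (0.26 log units; within the scatter) in this assay, and its exchange for 1-ethylpiperidin-4-yl gives a 1.8-fold lower number from compound 1 to compound 3 (0.25 log units; within the scatter). The earlier step changed only the group on the ring nitrogen, whereas these two steps replace the whole ring, bringing in a second hetero atom, a double bond outside aromatic rings and a second hydrogen-bond acceptor, yet neither step goes beyond the scatter. No measurement here offers an explanation for this result.

From the compounds shown here alone, the three compounds carry only six-membered non-aromatic rings at this position, so it remains open whether a simple hydrogen, an open-chain amine or a carboxylic acid on the same carbon would stay within the scatter too. Going by these compounds, the plain 4-methylpiperazin-1-yl ring, without the carbonyl, would show what the carbonyl contributes, and the four-carbon chain ending in a phenyl ring is the same throughout, so the effect of a shorter or longer chain also remains unknown.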